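Moving a Phenol Hydroxyl Around a Purine Anilino Ring

The source may hold more compounds than are shown below. What is called first, only, known or untested is meant among the compounds shown, and "the series" means these compounds.

Of the compounds shown here, three sharing one core have been measured in a functional assay on MCF7 cells (Homo sapiens) for inhibition, read by fluorescence, with a stated time of 72 h; on this read-out lower numbers stand for stronger inhibition of growth and higher numbers for weaker inhibition of growth. Compound 1 `CC(C)CCn1cnc2c(Nc3cccc(O)c3)nc(N[C@H]3CC[C@H](N)CC3)nc21` gives 12600 nM, the highest of the three numbers and therefore the weakest growth inhibition in the set. Compound 2 `CC(C)=CCn1cnc2c(Nc3cccc(Cl)c3)nc(N[C@H]3CC[C@H](N)CC3)nc21` gives 4200 nM, and compound 3 `COc1ccc(Cn2cnc3c(Nc4cccc(Cl)c4)nc(N[C@H]4CC[C@H](N)CC4)nc32)cc1` gives 4800 nM. Within the data shown here, the one single-point step among the measured compounds, a 1.1-fold higher number from compound 2 to compound 3 (0.06 log units; within the scatter), changes the chain on the ring nitrogen rather than the anilino group, and it left the read-out essentially unchanged.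

Compound 4 `CC(C)CCn1cnc2c(Nc3ccc(O)cc3)nc(N[C@H]3CC[C@H](N)CC3)nc21` is the next compound to be measured. It differs from compound 1 only on the anilino side: 4-hydroxyphenyl in place of 3-hydroxyphenyl on a nitrogen on an aromatic ring. Among the measured compounds shown here, no measured step touches the hydroxyphenyl group, so there is no direct precedent for this change; the only comparison available, from compound 2 to compound 3, speaks to another part of the molecule and was flat. On that basis the expected step of a 1.3-fold lower number from compound 1 to compound 4 (0.10 log units; within the scatter) is modest and its direction uncertain, with no strong reason to expect a move beyond the scatter. Compound 4 is therefore estimated to give 10000 nM in this assay, within a range of 3500 nM to 30000 nM.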

Compound 4, concentration for 50% growth inhibition: 3100 nM
The estimate for compound 4 lay 3.2-fold (0.51 log units) above the measured number; the whole stated range lies above it.
By their numbers in this assay, from the lowest: compounds 4, 2 and 3 (each within the scatter of the next); then compound 1.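

In this assay, the change from 3-hydroxyphenyl to 4-hydroxyphenyl on a nitrogen on an aromatic ring gives a 4.1-fold lower number from compound 1 to compound 4 (0.61 log units; beyond the scatter), with the same atoms joined differently and nothing else in the molecule altered. Among these compounds, the only earlier step, a 1.1-fold higher number from compound 2 to compound 3 (0.06 log units; within the scatter), concerned the chain on the ring nitrogen and stayed within the scatter, so this is the first sign that growth inhibition in this set responds to a change on the anilino side, and that the placing of the hydroxyl alone is enough to move the number beyond the scatter. No supporting data are available to explain why the 4-hydroxyphenyl group gives the lower number.

The compounds shown leave open whether the hydroxyl itself matters or whether another group at the same place, such as an amine or a carboxylic acid, would give a similar number. They also leave open whether the same change would give a step of similar size on a compound carrying a different chain on the ring nitrogen, such as the 4-methoxyphenyl-bearing chain of compound 3.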